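Lengthening an Ether Chain on Two Related Cores

The source may hold more compounds than are shown below. What is called first, only, known or untested is meant among the compounds shown, and "the series" means these compounds.

Three compounds have been measured in a functional assay on HepG2 cells (Homo sapiens) for cytotoxicity, read by MTT assay, with a stated time of 48 h; on this read-out higher numbers stand for weaker inhibition and lower numbers for stronger inhibition:

Compound 1, `CCCCOc1ccc2c(Cl)ccnc2c1`, gives 2640 nM.
Compound 2, `CCCCCCCCOc1ccc2c(Cl)ccnc2c1`, gives 2640 nM.
Compound 3, `CCOc1ccc2c(NCCN(C)C)ccnc2c1`, gives 5680 nM.

Compound 4, `CCCCCCOc1ccc2c(NCCN(C)C)ccnc2c1`, has not yet been measured in this assay. Compound 2 differs from compound 1 by butyl in place of hydrogen on a saturated chain carbon, four bonds along the chain from an oxygen on an aromatic ring. That change made a step of no change at the digits printed from compound 1 to compound 2 (within the scatter). How compound 3 differs from compound 1 is not broken down here; the two cores differ in more than one place. Compound 4 differs from compound 3 by butyl in place of hydrogen on a saturated chain carbon, two bonds along the chain from an oxygen on an aromatic ring. The two places differ: in the first pair the butyl enters four bonds along the chain from the oxygen, in the second pair two bonds along the chain, so this is the same kind of change rather than the same one. Since the earlier step gave no change within the scatter, the step from compound 3 to compound 4 is expected to be small as well, estimated at a 1.1-fold lower number from compound 3 to compound 4 (0.04 log units; within the scatter), resting on no change at the digits printed from compound 1 to compound 2 (within the scatter) applied to the value of compound 3, 5680 nM. Compound 4 is therefore estimated at 5200 nM in this assay, expected to fall between 2500 nM and 11000 nM.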

Compound 4, half-maximal inhibitory concentration: 1370 nM
Estimate against measurement, compound 4: 3.8-fold (0.58 log units) above, and the stated range ends above it.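

In this assay the butyl step on the core of compound 3 gives a 4.1-fold lower number from compound 3 to compound 4 (0.62 log units; beyond the scatter) and, set against the earlier step, it does not carry over unchanged from one core to the other: the same change on two cores in this assay, no change at the digits printed (within the scatter) from compound 1 to compound 2 and a 4.1-fold lower number (0.62 log units; beyond the scatter) from compound 3 to compound 4, 4.1-fold (0.62 log units) apart, beyond the scatter of two such steps. The size of this change therefore depends on the pair in which it is made, but the two pairs differ in more than the core, since the butyl enters four bonds along the chain from the oxygen in the first pair and two bonds along the chain in the second. Among the compounds shown here, with only one pair on each core, the comparison does not show whether the core or the place on the chain accounts for the gap.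

The compounds shown leave open how ethoxy and hexyloxy chains behave on the core of compound 1, and how butoxy and octyloxy chains behave on the core of compound 3, which would set matching chains side by side. They also leave open what an ether chain ending in an amine or a carboxylic acid would do on either core.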